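The source may hold more compounds than are shown below. What is called first, only, known or untested is meant among the compounds shown, and "the series" means these compounds.

Of the compounds shown here, three have been measured: compound 1 is `CSc1nc(NCCCCNc2ccnc3cc(Cl)ccc23)c(C#N)c(-c2ccccc2)n1`, compound 2 is `CSc1nc(OCCCNc2ccnc3cc(Cl)ccc23)c(C#N)c(-c2ccccc2)n1`, and compound 3 is `CSc1nc(NCCCCNc2ccnc3cc(Cl)ccc23)c(C#N)c(-c2ccc([N+](=O)[O-])cc2)n1`. In an ADME assay on MDCK cells (Canis lupus familiaris) for cytotoxicity, read by microscopy (a higher number here means that more compound is tolerated, a lower number that less compound is tolerated), compound 1 gives 20000 nM, compound 2 gives 4000 nM, and compound 3 gives 4000 nM. Compound 3 stands level with compound 2 at the digits shown, the two together the lowest of the three numbers, while compound 1 lies furthest from it. Within the data shown here, the one measured step involving a substituent on an aromatic carbon is a 5.0-fold lower number from compound 1 to compound 3 (0.70 log units; beyond the scatter).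

Compound 4 is `COc1cc(-c2nc(SC)nc(NCCCCNc3ccnc4cc(Cl)ccc34)c2C#N)cc(OC)c1OC` and has not yet been measured in this assay. It differs from compound 3 in one place: 3,4,5-trimethoxyphenyl in place of 4-nitrophenyl on an aromatic carbon. Among the measured compounds shown here, no measured step covers a trimethoxyphenyl group; the only comparable step, a 5.0-fold lower number from compound 1 to compound 3 (0.70 log units; beyond the scatter), shows that a change at this position can move the number beyond the scatter, but it does not tell the direction for this new group. The expectation for compound 4 therefore rests on compound 3 with 4000 nM as the anchor. The step expected is a 1.5-fold higher number from compound 3 to compound 4 (0.18 log units; within the scatter), modest and uncertain in direction. The estimate for compound 4 in this assay is 6000 nM, with a range from 2000 nM to 20000 nM.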

Compound 4, minimum cytotoxic concentration: 4000 nM
Estimate against measurement, compound 4: 1.5-fold (0.18 log units) above; the measured number falls inside the stated range.
By their numbers in this assay, from the lowest: compounds 2, 3 and 4 (each within the scatter of the next); then compound 1.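

In this assay, replacing 4-nitrophenyl with 3,4,5-trimethoxyphenyl on this aromatic carbon gives no change at the digits printed from compound 3 to compound 4 (within the scatter) and so shows that this position can take two quite different substituted phenyl groups without a change beyond the scatter. Against the plain phenyl group, the new group gives a 5.0-fold lower number from compound 1 to compound 4 (0.70 log units; beyond the scatter) and so adds a second case in which a substituted phenyl group goes with a lower number than phenyl, with no listed compound going against this. Nothing measured here explains why the two groups stand level.

As far as these compounds go, it remains open whether a single methoxy group, an amine or a carboxylic acid on this phenyl ring would give a similar number. From the compounds shown here alone, it is also open whether 3,4,5-trimethoxyphenyl would have the same effect on the core of compound 2.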